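The compounds below may be only part of what the source reports. "The series", "measured", "known", "first", "only" and "open" are said of these compounds alone.

Compound 1 `COc1ccc2[nH]cc(C(=O)/C(C#N)=C/C=C(\Cl)c3ccc(Br)cc3)c2c1`: > 100000 nM (a limit)
Compound 2 `N#C/C(=C\C=C(/Cl)c1ccc(Br)cc1)C(=O)c1c[nH]c2ccccc12`: 81500 nM
Compound 3 `COc1ccc(/C(Cl)=C/C=C(\C#N)C(=O)c2c[nH]c3ccccc23)cc1`: > 100000 nM (a limit)

In a functional assay on MCF7 cells (Homo sapiens) for cytotoxicity, read by sulforhodamine B assay, with a stated time of 48 h (on this read-out lower numbers stand for stronger inhibition of growth and higher numbers for weaker inhibition of growth), compound 2 gives 81500 nM. For compound 1 the assay reports only a limit, > 100000 nM. For compound 3 the assay likewise reports only a limit, > 100000 nM. The change methoxy in place of hydrogen on an aromatic carbon gave an at least 1.2-fold higher number from compound 2 to compound 1 (0.08 log units; that floor lies within the scatter), and the core change methoxy in place of bromo on an aromatic carbon gave an at least 1.2-fold higher number from compound 2 to compound 3 (0.08 log units; that floor lies within the scatter); both rest on (the limit of > 100000 nM in this assay, at which 2 of the 3 values shown sit).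

Compound 4 `COc1ccc(/C(Cl)=C/C=C(\C#N)C(=O)c2c[nH]c3ccccc23)cc1OC` differs from compound 3 by methoxy in place of hydrogen on an aromatic carbon. This is the same kind of change as that from compound 2 to compound 1, but not the same: there the methoxy entered on a ring that is part of a fused system, meta and para to a fused ring, whereas here it enters ortho to a methoxy group and meta to a large group. Since compound 3 already sits at the limit > 100000 nM, and the earlier step of an at least 1.2-fold higher number from compound 2 to compound 1 (0.08 log units; that floor lies within the scatter) brought no lower number, compound 4 is expected to show a step that the limit leaves unreadable from compound 3 to compound 4 and is estimated at 150000 nM, most likely again as a limit.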

Compound 4, concentration for total growth inhibition: > 100000 nM
Compound 4 gave a limit, no number; the forecaster's own chance of this, stated with the estimate: 80%; the middle value lies beyond the limit too.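

No step can be read between compound 3 and compound 4 in this assay, because each gives only a limit: (the limit of > 100000 nM in this assay, at which 3 of the 4 values shown sit). The compounds shown leave open whether this added methoxy changes growth inhibition at all.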